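Replacing a hydroxyl tail with a piperidine ring

A few compounds are considered here, and "the series" means these few. Any claim that something is new, unique, unknown or untested is made for them only; others in the source may bear on it.

Compound 2 `Cn1ncc(Cl)c1-c1cc(C(=O)N[C@@H]2CN[C@H](CCCO)C[C@H]2c2ccc(Cl)c(Cl)c2)oc1Cl` gives 2.56 nM in an assay for inhibition of RAC-alpha serine/threonine-protein kinase (Homo sapiens), read by HTRF, with a stated time of 1 h (on this read-out higher numbers stand for weaker inhibition and lower numbers for stronger inhibition), the lowest of the two numbers shown, although this sits within the scatter of compound 1 `CNC(=O)C[C@@H]1C[C@@H](c2ccc(Cl)c(Cl)c2)[C@H](NC(=O)c2cc(-c3c(Cl)cnn3C)c(Cl)o2)CN1`, which gives 2.64 nM. Among the compounds with values here, the one measured step, a 1.0-fold lower number from compound 1 to compound 2 (0.01 log units; within the scatter), changed the tail on the saturated ring carbon without moving the number beyond the scatter.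

Compound 3 `Cn1ncc(Cl)c1-c1cc(C(=O)N[C@@H]2CN[C@H](CCN3CCCCC3)C[C@H]2c2ccc(Cl)c(Cl)c2)oc1Cl` differs from compound 2 by piperidin-1-yl in place of hydroxymethyl on a saturated chain carbon, two bonds along the chain from a saturated ring carbon. The tail loses its single hydrogen-bond donor and gains a ring, while the rest of the shared core stays untouched.

Within the data shown here, only the step from compound 1 to compound 2 bears on this change, since it alters the same tail, and it was flat. Among the measured compounds shown here, no measured step shows what a ring at this position does, so the expectation rests on the observation that this tail has tolerated one exchange without a visible effect. The expected step for compound 3 is therefore a 1.0-fold lower number from compound 2 to compound 3 (0.01 log units; within the scatter), with a wider range than usual to reflect the larger change.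

Compound 3 is thus estimated at 2.5 nM in this assay, between 0.9 nM and 7 nM.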

Compound 3, half-maximal inhibitory concentration: 5.65 nM
For compound 3 the middle estimate is 2.3-fold (0.35 log units) below the measured one, within the range that was stated.
By their numbers in this assay, from the lowest: compounds 2 and 1 (each within the scatter of the next); then compound 3.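

In this assay, the earlier exchange of the tail, from methylcarbamoyl to 2-hydroxyethyl, left the number within the scatter, so this position could have seemed indifferent to what it carries. The piperidine changes that picture, with a 2.2-fold higher number from compound 2 to compound 3 (0.34 log units; beyond the scatter) and with a 2.1-fold higher number from compound 1 to compound 3 (0.33 log units; beyond the scatter) against the other earlier tail, so the position does respond to a change, though only modestly, and compound 3 at 5.65 nM remains a strong inhibitor on this read-out. No data are available here to explain the shift, so the measured step cannot be assigned to the added ring, to the larger tail or to the lost hydroxyl hydrogen-bond donor.

These three features change together in compound 3, which leaves their separate contributions unresolved. An open-chain amine such as dimethylamino, a morpholin-4-yl ring or a plain cyclohexyl ring at the same chain end would help to separate them, while a carboxylic acid or a longer chain would show how far this tail can vary before the number rises further.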